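This account rests on a few compounds, and the source may have more. Where it says the series, first, only, none or still open, it means among the compounds named here.

Compound 1 `CCOC(=O)c1ccc(NC(=O)N2CC2C#N)cc1` gives 5800 nM in a functional assay on A-375 cells (Homo sapiens) for inhibition (a lower number here means a stronger inhibitor, a higher number a weaker inhibitor), the lowest of the three numbers in hand. Compound 2 `CC(=O)c1cccc(NC(=O)N2CC2C#N)c1` gives 7900 nM in this assay; the two values lie within the scatter of each other, so no order between them is claimed. Compound 3 `CC(C)(C)NC(=O)N1CC1C#N` gives 418000 nM in this assay, a gap to compound 1 that lies well beyond the scatter. Among these three, the shared core with an aromatic ring on the urea thus appears to carry most of the inhibition seen, with compound 3 as the one example without it.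

Compound 4 `N#CC1CN1C(=O)Nc1ccc(F)cc1` has not yet been measured. It differs from compound 1 in one place: fluoro in place of ethoxycarbonyl on an aromatic carbon. Nothing in hand shows what a substituent on that aromatic ring contributes, beyond the fact that compound 1 and compound 2 sit close together with different groups. The step from compound 1 to compound 4 is expected to be small, within or only just beyond the scatter, and toward a higher number: a 1.9-fold higher number from compound 1 to compound 4 (0.28 log units; within the scatter). Compound 4 is estimated at 11000 nM, with a range from 3500 nM to 40000 nM.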

Compound 4, half-maximal inhibitory concentration: 3400 nM
Estimate against measurement, compound 4: 3.2-fold (0.51 log units) above; the whole stated range lies above it.
By their numbers in this assay, from the lowest: compounds 4, 1 and 2 (each within the scatter of the next, the first and the last beyond it); then compound 3.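

In this assay, fluoro in place of ethoxycarbonyl on an aromatic carbon, para to a group of 8 heavy atoms, gives a 1.7-fold lower number from compound 1 to compound 4 (0.23 log units; within the scatter) and so stays within the scatter. At this position, then, the level of inhibition seen in compound 1 does not depend on keeping the ethoxycarbonyl group with its 2 hydrogen-bond acceptors, since compound 4 carries fluoro with none and still reads alike. No measurement in hand bears on why these two groups read alike.

Open, as far as these compounds go, is whether an amine, a carboxylic acid or a longer chain at this position would give a step beyond the scatter, or would also read alike. Also open, from the compounds shown here alone, is what a plain hydrogen there would give, as a single step within the scatter sets no trend for this position.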